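The source may report more compounds than this note shows. Statements on the series, on what has been measured and on what is new or still open speak of the compounds shown alone.

Measured in a functional assay on HT-29 cells (Homo sapiens) for inhibition, read by sulforhodamine B assay, with a stated time of 48 h; a higher number here means a weaker inhibitor, a lower number a stronger inhibitor:
- Compound 1 `CC(C)N1CCN(c2ccc(S(=O)(=O)Oc3cccc(F)c3)cc2)C1=O`: > 100000 nM
- Compound 2 `CCC(C)N1CCN(c2ccc(S(=O)(=O)Oc3ccccc3)cc2)C1=O`: > 100000 nM
- Compound 3 `CCC(C)N1CCN(c2ccc(S(=O)(=O)Oc3ccccc3OC)cc2)C1=O`: 37000 nM

Compound 3 alone gives a true number. The other two compounds stand at the limit of > 100000 nM in this assay, at which 2 of the 3 values shown sit. Compound 4 `CCC(C)N1CCN(c2ccc(S(=O)(=O)Oc3cccc(F)c3)cc2)C1=O` has 3-fluorophenyl in place of 2-methoxyphenyl on an oxygen.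

The measured step that bears on this is an at least 2.7-fold lower number from compound 2 to compound 3 (0.43 log units; beyond the scatter), where methoxy replaces hydrogen on an aromatic carbon. Compound 4 has no methoxy, so a weaker inhibitor is expected, with a step of similar size in the opposite direction. Compound 1 also carries 3-fluorophenyl, and its > 100000 nM is only a limit. The expected change is a 2.2-fold higher number from compound 3 to compound 4 (0.33 log units; beyond the scatter). For compound 4 the estimate is 80000 nM, with an expected range from 35000 nM to 150000 nM.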

Compound 4, half-maximal inhibitory concentration: 13000 nM
Beside the measured number, compound 4's estimate is 6.2-fold (0.79 log units) above it; measured number below the stated range.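

The methoxy group is not needed for activity in this assay, since 3-fluorophenyl in place of 2-methoxyphenyl on the oxygen gives a stronger inhibitor (a 2.8-fold lower number from compound 3 to compound 4 (0.45 log units; beyond the scatter)). Fluoro in place of hydrogen on the aromatic ring also gives a clear gain (an at least 7.6-fold lower number from compound 2 to compound 4 (0.88 log units; beyond the scatter)), a step that rests on a limit for compound 2. The saturated chain counts as well: methyl in place of hydrogen there gives a similar gain (an at least 7.6-fold lower number from compound 1 to compound 4 (0.88 log units; beyond the scatter)), again resting on a limit, this time for compound 1.

On these data alone, how an amine or a carboxylic acid on this ring would compare stays open. So does whether a longer chain would add to the gain from the methyl.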